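This account rests on a few compounds, and the source may have more. Where it says the series, first, only, none or still open, it means among the compounds named here.

Measured so far in a functional assay on NCI-H522 cells (Homo sapiens) for inhibition, read by sulforhodamine B assay, with a stated time of 48 h; on this read-out lower numbers stand for stronger inhibition of growth and higher numbers for weaker inhibition of growth:
- compound 1 `Cc1ccc(NC(=O)/C=C/c2ccccc2)c(C(N)=O)c1`: 2830 nM
- compound 2 `NC(=O)c1cc(Br)ccc1NC(=O)/C=C/c1ccccc1`: "not determined" (no result reported)

Among the measured compounds shown here, compound 2 has no single number in this assay, so its standing cannot be read and no measured step starts from it. The next analogue is compound 3 `NC(=O)c1cc(I)ccc1NC(=O)/C=C/c1ccccc1`, with the change iodo in place of bromo on an aromatic carbon, meta to a carbamoyl group and para to a large group.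

For the measured compounds named here, no measured step shows what this change does. No step beyond the usual scatter is expected between compound 2 and compound 3 in this assay, and no direction can be assigned. Going by the values given here, the only numerical anchor is compound 1 at 2830 nM, and the expectation stays close to that value, with a wide margin. The estimate for compound 3 is 2500 nM, expected to fall within 800 nM to 8000 nM.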

Compound 3, concentration for 50% growth inhibition: 303 nM
Estimate against measurement, compound 3: 8.3-fold (0.92 log units) above; measured number outside the range, below it.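

In this assay, exchanging the methyl group for iodo, meta to a carbamoyl group and para to a large group, gives a 9.3-fold lower number from compound 1 to compound 3 (0.97 log units; beyond the scatter) and this step lies beyond the scatter. Among the compounds shown here, this is the first sign that growth inhibition responds to the group at this position, which compound 1 alone could not show. The bromo to iodo step cannot be read, since compound 2 has no single number, and nothing at hand accounts for the step from methyl to iodo.

As far as these compounds go, whether the lower number is particular to iodo or extends to other halogens therefore stays open. How a chloro or fluoro group, an amine, a carboxylic acid or a longer chain such as propyl would read at this position also remains unknown from the compounds shown.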